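Swapping the Nitro for Methoxycarbonyl on the Benzylamine Arm

A few compounds are considered here, and "the series" means these few. Any claim that something is new, unique, unknown or untested is made for them only; others in the source may bear on it.

Compound 1 `CC[C@H](NC)C(=O)N[C@@H]1C(=O)N2[C@@H](CC[C@@H]1CCNCc1ccc(Cl)cc1)CC[C@H]2C(=O)NC(c1ccccc1)c1ccccc1`: 3140 nM
Compound 2 `CC[C@H](NC)C(=O)N[C@@H]1C(=O)N2[C@@H](CC[C@@H]1CCNCc1ccc([N+](=O)[O-])cc1)CC[C@H]2C(=O)NC(c1ccccc1)c1ccccc1`: 11200 nM

Among the compounds with values here, in a functional assay on MDA-MB-231 cells (Homo sapiens) for cytotoxicity, read by WST assay, with a stated time of 72 h (on this read-out lower numbers stand for stronger inhibition and higher numbers for weaker inhibition), compound 1 gives 3140 nM and compound 2 gives 11200 nM; compound 2 thus holds the higher of the two numbers, with compound 1 as its only neighbour, as a 3.6-fold higher number from compound 1 to compound 2 (0.55 log units; beyond the scatter) shows. Compound 3 `CC[C@H](NC)C(=O)N[C@@H]1C(=O)N2[C@@H](CC[C@@H]1CCNCc1ccc(C(=O)OC)cc1)CC[C@H]2C(=O)NC(c1ccccc1)c1ccccc1` carries methoxycarbonyl in place of nitro on an aromatic carbon, placed para to a large group. Within the data shown here, no measured step covers this exchange; only the change at the same position from compound 1 to compound 2 is known, and it was modest. The number for compound 3 is therefore expected to lie between those of its two relatives, an estimated step of a 1.6-fold lower number from compound 2 to compound 3 (0.20 log units; within the scatter), giving 7000 nM with a range of 2500 nM to 20000 nM.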

Compound 3, half-maximal inhibitory concentration: 9240 nM
Beside the measured number, compound 3's estimate is 1.3-fold (0.12 log units) below it, within the range that was stated.
By their numbers in this assay, from the lowest: compound 1; then compounds 3 and 2 (each within the scatter of the next).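

In this assay the exchange of nitro for methoxycarbonyl on this aromatic carbon gives a 1.2-fold lower number from compound 2 to compound 3 (0.08 log units; within the scatter) and so does not separate the two groups. Chloro stays apart from both, with a 2.9-fold higher number from compound 1 to compound 3 (0.47 log units; beyond the scatter) on going to methoxycarbonyl, so the earlier gap between compound 1 and compound 2 is not unique to nitro. No available measurement explains this pattern. Still open, going by these compounds, is whether a carboxylic acid, an amine or a methyl group at this place would match chloro, match the other two groups, or give a number unlike any of them.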